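A ring swap on the side chain of compound 1

The source may hold more compounds than are shown below. What is called first, only, known or untested is meant among the compounds shown, and "the series" means these compounds.

Compound 1 `CC(C)C(c1ncco1)c1ccc(-c2ccc3cccc(F)c3c2)[nH]c1=O` was tested in an ADME assay on microsomes from liver (Mus musculus) for metabolic stability (on this read-out higher numbers stand for a longer-lived compound and lower numbers for a shorter-lived compound), where compound 1 gives 0.08 h. Compound 2 `CCn1ncc2c(F)cc(-c3ccc(C(CC)(CC)c4nnc(C)[nH]4)c(=O)[nH]3)cc21` is reported in this assay as > 3 h, which is a limit of the assay and not a number. Compound 1 thus carries the only plain number shown, with the other result sitting at the limit (the limit of > 3 h in this assay, at which 1 of the 2 values shown sits). Compound 3 `CC(C)C(c1ccc(-c2ccc3cccc(F)c3c2)[nH]c1=O)N1CCNC1=O` differs from compound 1 in one place: 2-oxoimidazolidin-1-yl in place of 1,3-oxazol-2-yl on a saturated chain carbon bound to an aromatic carbon and a saturated chain carbon. For the measured compounds named here, with no measured step between related compounds available, the step of a 2.5-fold higher number from compound 1 to compound 3 (0.40 log units; beyond the scatter) is expected to be modest, toward a longer-lived compound. Compound 3 is estimated at 0.2 h, within a range from 0.05 h to 0.8 h.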

Compound 3, half-life: 0.682 h
Beside the measured number, compound 3's estimate is 3.4-fold (0.53 log units) below it; the range from low to high includes it.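

On the saturated chain carbon, the choice of ring clearly matters in this assay: 2-oxoimidazolidin-1-yl in place of 1,3-oxazol-2-yl gives an 8.5-fold higher number from compound 1 to compound 3 (0.93 log units; beyond the scatter), so this position responds to a ring swap, at least in this single pair. A non-aromatic ring with a hydrogen-bond donor is thus accepted here with no loss of lifetime. Nothing measured here accounts for the rise.

Going by these compounds, whether the loss of aromaticity or the added donor hydrogen counts more remains open. So does how a morpholine ring or an open-chain urea would behave on this carbon.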